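Swapping the amide group on a shared dimethoxy core

A few compounds are considered here, and "the series" means these few. Any claim that something is new, unique, unknown or untested is made for them only; others in the source may bear on it.

Three compounds sharing one core were tested in a functional assay on the whole organism (strain Wistar) for inhibition, with Rattus norvegicus as the target, read by paw edema, with stated times of 60 min and 2 h, at a dose of 100 mg/kg by the oral route; on this read-out higher numbers stand for more inhibition at the one dose given (going by the name of the read-out) and lower numbers for less inhibition:

Compound 1, `CCNC(=O)CC1CCc2cc(OC)c(OC)cc21`: 26%
Compound 2, `CCN(CC)C(=O)CC1CCc2cc(OC)c(OC)cc21`: 40%
Compound 3, `CCCCCCNC(=O)CC1CCc2cc(OC)c(OC)cc21`: 41.5%

Compound 3 holds the highest of the three numbers, but its nearest neighbour, compound 2, sits within the scatter of it: a number 1.5 percentage points higher from compound 2 to compound 3 (within the scatter). Only compound 1 lies clearly lower, as a number 15.5 percentage points higher from compound 1 to compound 3 (beyond the scatter) shows, and the same gap appears in a number 14 percentage points higher from compound 1 to compound 2 (beyond the scatter).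

Compound 4, `COc1cc2c(cc1OC)C(CC(=O)N1CCOCC1)CC2`, differs from compound 3 in one place: morpholin-4-yl in place of hexylamino on a carbonyl carbon. The step that bears on this is a number 14 percentage points higher from compound 1 to compound 2 (beyond the scatter), where a nitrogen bearing a hydrogen became one bearing two carbons; that is also the direction of the present change. On the other hand, a number 1.5 percentage points higher from compound 2 to compound 3 (within the scatter) shows that a tertiary and a secondary amide can sit level. Among the measured compounds shown here, no measured step involves a ring on the amide nitrogen, so the morpholin-4-yl group itself is untested ground. The expectation is therefore that compound 4 will land close to compound 2 and compound 3, with a number 3.5 percentage points lower from compound 3 to compound 4 (within the scatter) staying within the usual scatter. Compound 4 is estimated at 38%, in a range from 22% to 52%.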

Compound 4, a percentage reported as inhibition, in the whole organism at one dose (the size of the read-out at that dose, not a potency): 14%
The estimate for compound 4 lay 24 percentage points above the measured number; the whole stated range lies above it.
By their numbers in this assay, from the lowest: compound 4; then compound 1; then compounds 2 and 3 (each within the scatter of the next).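

Among the amides shown, morpholin-4-yl on the carbonyl carbon is the first group to bring the number down sharply in this assay, both against the hexylamino group of compound 3 (a number 27.5 percentage points lower from compound 3 to compound 4 (beyond the scatter)) and against the diethylamino group of compound 2 (a number 26 percentage points lower from compound 2 to compound 4 (beyond the scatter)). Compound 2 and compound 4 both have an amide nitrogen without a hydrogen, so the absence of that hydrogen cannot by itself set the result, and the earlier gain from ethylamino to diethylamino does not carry over to every such amide. Morpholin-4-yl also falls short of the small ethylamino group of compound 1 (a number 12 percentage points lower from compound 1 to compound 4 (beyond the scatter)), which leaves compound 4 clearly lowest of the four, though no measurement given here explains this drop.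

The compounds shown cannot separate the effect of closing the two nitrogen substituents into a ring from the effect of the oxygen in that ring. Piperidin-1-yl, the same six-membered ring with carbon in place of the oxygen, would pull those two apart, and pyrrolidin-1-yl would test a smaller ring on the same carbonyl carbon.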